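Replacing Piperidin-1-yl with Pyridin-2-yl in Compound 3

The source may report more compounds than this note shows. Statements on the series, on what has been measured and on what is new or still open speak of the compounds shown alone.

In a functional assay on MIA PaCa-2 cells (Homo sapiens) for cytotoxicity, read by MTT assay, with a stated time of 72 h (a higher number here means a weaker inhibitor, a lower number a stronger inhibitor), compound 1 (`CN1CCN(c2ccc(NC3=CC(=O)c4ncncc4C3=O)cc2)CC1`) gives 530 nM, compound 2 (`O=C1C(Nc2ccc(C3CCCCC3)cc2)=CC(=O)c2ncncc21`) gives 1200 nM and compound 3 (`O=C1C(Nc2ccc(N3CCCCC3)cc2)=CC(=O)c2ncncc21`) gives 2400 nM. Two steps fix the standing of the last: a 2.0-fold higher number from compound 2 to compound 3 (0.30 log units; within the scatter), and a 4.5-fold higher number from compound 1 to compound 3 (0.66 log units; beyond the scatter). Compound 4 (`O=C1C(Nc2ccc(-c3ccccn3)cc2)=CC(=O)c2ncncc21`) carries pyridin-2-yl in place of piperidin-1-yl on an aromatic carbon. Among the measured compounds shown here, no measured step makes this exchange. The closest evidence is the ring exchanges on that carbon, those two steps and a 2.3-fold higher number from compound 1 to compound 2 (0.35 log units; beyond the scatter), all modest or smaller. No step beyond the scatter is therefore expected in this assay. The expected change is a 1.5-fold lower number from compound 3 to compound 4 (0.18 log units; within the scatter). Compound 4 is estimated at 1600 nM, with an expected range of 500 nM to 5000 nM.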

Compound 4, half-maximal inhibitory concentration: 2000 nM
Estimate against measurement, compound 4: 1.3-fold (0.10 log units) below, within the range that was stated.
By their numbers in this assay, from the lowest: compound 1; then compounds 2, 4 and 3 (each within the scatter of the next).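

In this assay, exchanging a non-aromatic ring for an aromatic one of the same size on this carbon gives no step beyond the scatter (a 1.2-fold lower number from compound 3 to compound 4 (0.08 log units; within the scatter)), and pyridin-2-yl also stays within the scatter of cyclohexyl (a 1.7-fold higher number from compound 2 to compound 4 (0.22 log units; within the scatter)). Only 4-methylpiperazin-1-yl remains apart from the new compound (a 3.8-fold higher number from compound 1 to compound 4 (0.58 log units; beyond the scatter)). No evidence given here bears on this result.

As far as these compounds go, it remains open how an unsubstituted piperazin-1-yl, a morpholin-4-yl or a carboxylic acid would read on this carbon. From the compounds shown here alone, the effect of moving the pyridine nitrogen within the ring also remains open.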